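Chloro to trifluoromethyl on the urea aryl ring

The compounds below may be only part of what the source reports. "The series", "measured", "known", "first", "only" and "open" are said of these compounds alone.

Within the data shown here, compound 2 `O=C(Nc1cccc(-n2cc(-c3ccncc3)c(-c3ccc(Cl)c(O)c3)n2)c1)Nc1ccc(Cl)c(Cl)c1` is one of two compounds measured in a functional assay on SK-MEL-5 cells (Homo sapiens) for inhibition, read by sulforhodamine B assay, with a stated time of 48 h (a higher number here means a weaker inhibitor of growth, a lower number a stronger inhibitor of growth), where compound 2 gives 1160 nM. Among the measured compounds shown here, its only measured neighbour is compound 1 `COc1cc(-c2nn(-c3cccc(NC(=O)Nc4ccc(Cl)c(Cl)c4)c3)cc2-c2ccncc2)ccc1Cl`, which in this assay gives 1490 nM; the step of a 1.3-fold lower number from compound 1 to compound 2 (0.11 log units; within the scatter) leaves the two within the scatter of each other. Compound 3 `O=C(Nc1cccc(-n2cc(-c3ccncc3)c(-c3ccc(Cl)c(O)c3)n2)c1)Nc1ccc(Cl)c(C(F)(F)F)c1` differs from compound 2 at another place: trifluoromethyl in place of chloro on an aromatic carbon. For the measured compounds named here, no measured step touches this part of the molecule, so the single step seen, at the methoxy-to-hydroxy position, bears on it only by showing that one small change elsewhere moved this assay little. In this assay compound 3 is therefore expected to show no step beyond the scatter, with an estimated step of a 1.1-fold lower number from compound 2 to compound 3 (0.02 log units; within the scatter). The estimate for compound 3 in this assay is 1100 nM, with a range from 450 nM to 2700 nM.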

Compound 3, concentration for total growth inhibition: 1080 nM
Compound 3: the middle estimate sits 1.0-fold (0.01 log units) above what was measured; the measured number falls inside the stated range.
By their numbers in this assay, from the lowest: compounds 3, 2 and 1 (each within the scatter of the next).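

Trifluoromethyl in place of chloro on the urea aryl ring gives a 1.1-fold lower number from compound 2 to compound 3 (0.03 log units; within the scatter) in this assay, so this is the first measured change at this part of the molecule, which the step between the earlier compounds did not touch. At this place, ortho to a chloro group, a group of 4 heavy atoms thus stands in for one of 1 heavy atom with no step beyond the scatter. No measurement of any other kind bears on this result.

On these data alone, whether the same holds for a nitrile, an amine or a carboxylic acid at this place stays open. So does whether trifluoromethyl would give the same result on the methoxy form of the shared core, since the two changes are seen only separately.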